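Amine capping on the pyrrolidine of the quinoline amide series

The compounds below may be only part of what the source reports. "The series", "measured", "known", "first", "only" and "open" are said of these compounds alone.

Compounds measured so far:
compound 1 `CN(c1ccc2cc(NC(=O)CCc3ccc(C(F)(F)F)cc3)ccc2n1)C1CCCCC1` — 18 nM
compound 2 `NC1CCN(c2ccc3cc(NC(=O)CCc4ccc(C(F)(F)F)cc4)ccc3n2)C1` — 12 nM
compound 3 `CCN(CC)c1ccc2cc(NC(=O)CCc3ccc(C(F)(F)F)cc3)ccc2n1` — 88 nM

In an assay on isolated protein for displacement of a labelled ligand from melanin-concentrating hormone receptor 1 (Homo sapiens) (on this read-out lower numbers stand for stronger inhibition and higher numbers for weaker inhibition), compound 2 gives the lowest number of the three, yet the step of a 1.5-fold lower number from compound 1 to compound 2 (0.18 log units; within the scatter) leaves it indistinguishable from compound 1. Only compound 3 stands apart: a 4.9-fold higher number from compound 1 to compound 3 (0.69 log units; beyond the scatter) and a 7.3-fold higher number from compound 2 to compound 3 (0.87 log units; beyond the scatter) are both modest losses.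

Compound 4 `CNC(=O)NC1CCN(c2ccc3cc(NC(=O)CCc4ccc(C(F)(F)F)cc4)ccc3n2)C1` keeps the shared core and the 3-aminopyrrolidin-1-yl attachment of compound 2 and changes it as follows: methylcarbamoyl in place of hydrogen on an amine nitrogen.

Within the data shown here, none of the measured steps touches this position; they all exchange the whole substituent on the aromatic carbon, not a hydrogen on the amine nitrogen. The nearest guidance is that the substituent at that carbon tolerates a swap from cyclohexyl(methyl)amino to 3-aminopyrrolidin-1-yl within the scatter, while diethylamino costs a modest factor. A capping group on the amine is therefore expected to stay in this assay within a modest range of compound 2, most likely on the weaker side, with a 2.5-fold higher number from compound 2 to compound 4 (0.40 log units; beyond the scatter) as the expected step.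

Compound 4 is estimated at 30 nM in this assay, with a range of 8 nM to 120 nM.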

Compound 4, half-maximal inhibitory concentration: 6 nM
The estimate for compound 4 lay 5.0-fold (0.70 log units) above the measured number; the measured number lies below the stated range.
By their numbers in this assay, from the lowest: compounds 4, 2 and 1 (each within the scatter of the next, the first and the last beyond it); then compound 3.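

Within this assay the amino group of compound 2 can be exchanged for (methylcarbamoyl)amino with no loss beyond the scatter, as a 2.0-fold lower number from compound 2 to compound 4 (0.30 log units; within the scatter) shows, so a free amino group on this ring carbon is not needed to hold the number in this range. The capped substituent also separates from the acyclic amines in a way that the uncapped one did not fully do: a 3.0-fold lower number from compound 1 to compound 4 (0.48 log units; beyond the scatter) lies beyond the scatter, where compound 2 could not be told apart from compound 1, and a 15-fold lower number from compound 3 to compound 4 (1.17 log units; beyond the scatter) is the largest step in the set. No measurement at hand gives a reason for this tolerance of the cap.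

The compounds shown carry a single cap on this amine nitrogen, so it stays open whether an acetyl group, a methylsulfonyl group or a longer chain such as ethylcarbamoyl would behave like methylcarbamoyl in this assay and hold the number in this range. Also open, going by these compounds, is whether the remaining hydrogen on that nitrogen or on the methylamino end of the cap matters, which a dimethylcarbamoyl group would begin to address.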